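This account rests on a few compounds, and the source may have more. Where it says the series, first, only, none or still open, it means among the compounds named here.

The measured compounds and their readings in an assay for inhibition of serine/threonine-protein kinase Sgk1 (Homo sapiens), with stated times of 30 min and 60 min, in the presence of a further agent that is not named here; on this read-out lower numbers stand for stronger inhibition and higher numbers for weaker inhibition:

Compound 1, `O=C(N[C@@H]1CCNC1)c1cc(-c2ccc(NS(=O)(=O)c3cccc(Cl)c3Cl)cc2)nc2[nH]ncc12`, reaches only the limit of the assay, < 1 nM.
Compound 2, `CNC(=O)c1cc(-c2ccc(NS(=O)(=O)c3cccc(Cl)c3Cl)cc2)nc2[nH]ncc12`, gives 4 nM.
Compound 3, `CCOc1nc(-c2ccc(NS(=O)(=O)c3cc(Cl)ccc3F)cc2)nc2[nH]nc(C)c12`, gives 23 nM.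

Of the two readings that are numbers rather than limits, compound 3 stands at the higher one, weaker than compound 2 by a margin beyond the usual scatter, while compound 1 sits at the limit and cannot be ranked more closely.

Compound 4 is `CCN1CCCC(Oc2nc(-c3ccc(NS(=O)(=O)c4cc(Cl)ccc4F)cc3)nc3[nH]nc(C)c23)C1`. Against compound 3 the change is 1-ethylpiperidin-3-yl in place of ethyl on an oxygen on an aromatic ring. For the measured compounds named here, one measured step bears on it: an at least 4.0-fold higher number from compound 1 to compound 2 (0.60 log units; beyond the scatter), where a saturated nitrogen-containing ring gave way to a small alkyl group and the number rose. That step sits on an amide-type nitrogen, not on the ring oxygen changed here, and its size is only a lower bound because of the limit of < 1 nM in this assay, at which 1 of the 3 values shown sits. Read in the opposite direction, it points to a gain of at least modest size when such a ring enters in place of a small alkyl.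

Compound 4 is therefore expected to show a lower number than compound 3, with the expected step being a 2.9-fold lower number from compound 3 to compound 4 (0.46 log units; beyond the scatter). The estimated value of compound 4 is 8 nM, in the range 2 nM to 30 nM.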

Compound 4, half-maximal inhibitory concentration: 6 nM
Beside the measured number, compound 4's estimate is 1.3-fold (0.12 log units) above it, and the stated range covers the measured number.
By their numbers in this assay, from the lowest: compounds 2 and 4 (each within the scatter of the next); then compound 3. At a limit, below all of these: compound 1.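

In this assay, the oxygen on the aromatic ring, which carried only ethyl in compound 3, accepts the much larger 1-ethylpiperidin-3-yl with a gain rather than a loss, giving a 3.8-fold lower number from compound 3 to compound 4 (0.58 log units; beyond the scatter). For the compounds shown here, the direction agrees with the earlier change on the amide-type nitrogen, an at least 4.0-fold higher number from compound 1 to compound 2 (0.60 log units; beyond the scatter), so a saturated nitrogen-containing ring goes with the lower number at two different attachment points, on two different cores, although these two pairs are the only evidence for this. The new step also has a measured number at both ends, whereas the earlier one gives only a lower bound on its size: the limit of < 1 nM in this assay, at which 1 of the 4 values shown sits.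

The compounds shown leave open whether the gain depends on the ring nitrogen or simply on the ring, a question that a cyclohexyl group, with carbon in place of that nitrogen, would address. They also leave open what the ethyl on the ring nitrogen contributes and whether a ring is needed at all, which the unsubstituted piperidin-3-yl group and an open-chain amine such as 2-(diethylamino)ethyl would test.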